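Hydrogen for methyl on the aromatic nitrogen of compound 2

The source may hold more compounds than are shown below. What is called first, only, known or untested is meant among the compounds shown, and "the series" means these compounds.

Measured in an ADME assay on BHK cells (Mesocricetus auratus) for cytotoxicity, read by MTT assay, with a stated time of 96 h; on this read-out higher numbers stand for lower toxicity in this test and lower numbers for higher toxicity in this test:
compound 1 `CN1CCN(CC(=O)Nc2ccc(-c3nc4cc(C(F)(F)F)ccc4n3C)cc2)CC1` gives 16000 nM.
compound 2 `CC(=O)Nc1ccc(-c2nc3cc(C(F)(F)F)ccc3n2C)cc1` gives > 100000 nM, which is a limit of the assay.
compound 3 `CCN(CC)CC(=O)Nc1ccc(-c2nc3cc(C(F)(F)F)ccc3n2C)cc1` gives 16000 nM.

Compound 2 thus stands at the limit of > 100000 nM in this assay, at which 1 of the 3 values shown sits. The two steps that reach it, an at least 6.2-fold higher number from compound 1 to compound 2 (0.79 log units; beyond the scatter) and an at least 6.2-fold lower number from compound 2 to compound 3 (0.79 log units; beyond the scatter), run against a limit, whereas the remaining step is no change at the digits printed from compound 1 to compound 3 (within the scatter). Compound 4 `CC(=O)Nc1ccc(-c2nc3cc(C(F)(F)F)ccc3[nH]2)cc1` differs from compound 2 by hydrogen in place of methyl on an aromatic nitrogen. Going by the values given here, every measured step alters the group on the saturated chain carbon bound to the carbonyl carbon; none touches the aromatic nitrogen, so no measured step bears on this change. In this assay no step beyond the scatter is expected. Compound 4 is expected at 100000 nM, within 40000 nM to 300000 nM, most likely again as a limit. For compound 4 the expected step is a number no higher from compound 2 to compound 4 (the limit leaves the size open), an estimate only.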

Compound 4, half-maximal cytotoxic concentration: 53000 nM
The estimate for compound 4 lay 1.9-fold (0.28 log units) above the measured number; measured number inside the range.
By their numbers in this assay, from the lowest: compounds 1 and 3 (each within the scatter of the next); then compound 4. At a limit, above all of these: compound 2.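

In this assay, going by these compounds alone, the aromatic nitrogen is the first position to be varied apart from the chain carbon, and hydrogen in place of methyl gives an at least 1.8-fold lower number from compound 2 to compound 4 (0.27 log units; that floor lies within the scatter). Compound 4 thus has a measured number, whereas the value of compound 2 is a limit. The size of this change stays unresolved because one end of the step is a limit: the limit of > 100000 nM in this assay, at which 1 of the 4 values shown sits.

On these data alone, it remains open whether an ethyl group or a longer chain on this aromatic nitrogen would read like methyl or like hydrogen. As far as these compounds go, it is also open whether the same change would shift the number when diethylamino or 4-methylpiperazin-1-yl sits on the chain carbon.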